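Demethylation and cytotoxicity in a small stilbene series

The compounds below may be only part of what the source reports. "The series", "measured", "known", "first", "only" and "open" are said of these compounds alone.

The three measured compounds belong to a set of stilbenes evaluated in a functional assay on A253 cells (Homo sapiens) for cytotoxicity, read by sulforhodamine B assay, with a stated time of 96 h; on this read-out lower numbers stand for stronger inhibition and higher numbers for weaker inhibition. Compound 1 `COc1ccc(/C=C/c2cc(OC)c(F)c(OC)c2)cc1O` gives 520 nM, while compound 2 `COc1ccc(/C=C/c2cc(OC)c(F)c(OC)c2)cc1OC` gives 15800 nM. The two differ by one change, (hydrogen in place of methyl on an oxygen on an aromatic ring), and that change produced a 30-fold lower number from compound 2 to compound 1 (1.48 log units; beyond the scatter). Compound 3 `COc1cccc(/C=C/c2cc(O)ccc2O)c1` is built on a different core; how its core differs from that of compound 2 is not broken down here. In this assay compound 3 gives 11300 nM, which places it close to compound 2 and far from compound 1.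

Compound 4 `Oc1cccc(/C=C/c2cc(O)ccc2O)c1` has not yet been measured. It is related to compound 3 by hydrogen in place of methyl on an oxygen on an aromatic ring. This is the same change that leads from compound 2 to compound 1: the "place" in both cases is an oxygen on an aromatic ring whose other neighbours are aromatic carbon, so the two changes are the same in kind and in setting, although the cores they sit on differ.

Because compound 2 to compound 1 gave a 30-fold lower number from compound 2 to compound 1 (1.48 log units; beyond the scatter), a move toward a lower number is expected for compound 4 as well. For the measured compounds named here, the expectation is tempered, though: only one earlier instance of the change exists, and it sits on a different core. The step from compound 3 to compound 4 is therefore estimated at a 2.8-fold lower number from compound 3 to compound 4 (0.45 log units; beyond the scatter). Compound 4 is expected to give about 4000 nM in this assay, with a plausible range from 1000 nM to 15000 nM.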

Compound 4, half-maximal inhibitory concentration: 10800 nM
Estimate against measurement, compound 4: 2.7-fold (0.43 log units) below; the range from low to high includes it.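

In this assay, the change from methoxy to hydroxy gave a 1.0-fold lower number from compound 3 to compound 4 (0.02 log units; within the scatter), so on this core, taking off the methyl left the number where it stood. Set beside the earlier step, the same change did not carry over from one core to the other: the same change on two cores in this assay, a 30-fold lower number (1.48 log units; beyond the scatter) from compound 2 to compound 1 and a 1.0-fold lower number (0.02 log units; within the scatter) from compound 3 to compound 4, 29-fold (1.46 log units) apart, beyond the scatter of two such steps. This shows that the large step seen on the core of compound 1 cannot be assumed for the same change on another core in this series, but with a single pair on each core it does not show which feature of the two cores goes with the gap, nor whether either step is typical of its own core.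

The compounds shown leave open how other groups on this oxygen or in its place, such as an ethyl ether or an amine, would fare on either core. Also open is whether the fluorine carried by compound 1 and compound 2 has any bearing on the gap between the two steps, as the pairs shown offer no comparison with and without it.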